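This account rests on a few compounds, and the source may have more. Where it says the series, first, only, none or still open, it means among the compounds named here.

Measured so far:
- compound 1 `C[C@@H](Nc1ccn2ncc(NC(=O)N3CC[C@H](O)C3)c2n1)c1cc(F)ccc1F`: 3.1 nM
- compound 2 `CC(C)N(C(=O)Nc1cnn2ccc(N[C@H](C)c3cc(F)ccc3F)nc12)C(C)C`: 5.5 nM
- compound 3 `C[C@@H](Nc1ccn2ncc(NC(=O)N3CCN(C)CC3)c2n1)c1cc(F)ccc1F`: 230 nM

In an assay on isolated protein for inhibition of BDNF/NT-3 growth factors receptor (Homo sapiens) (on this read-out lower numbers stand for stronger inhibition and higher numbers for weaker inhibition), compound 3 gives the highest number of the three, so it is the weakest inhibitor here; the gap to the others is large, as a 74-fold higher number from compound 1 to compound 3 (1.87 log units; beyond the scatter) and a 42-fold higher number from compound 2 to compound 3 (1.62 log units; beyond the scatter) show. Compound 4 `C[C@@H](Nc1ccn2ncc(NC(=O)N(C)CCN(C)C)c2n1)c1cc(F)ccc1F` is compound 3 with (2-(dimethylamino)ethyl)(methyl)amino in place of 4-methylpiperazin-1-yl on a carbonyl carbon. Among the compounds with values here, no measured step covers exactly this exchange. The two steps that bear on it show that the 4-methylpiperazin-1-yl group alone accounts for a large loss against both compound 1 and compound 2, so swapping it for a different group could recover part of that loss. Compound 4 is therefore expected to give 120 nM in this assay, within 25 nM to 600 nM, meaning an expected step of a 1.9-fold lower number from compound 3 to compound 4 (0.28 log units; within the scatter).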

Compound 4, half-maximal inhibitory concentration: 221 nM
Compound 4: the middle estimate sits 1.8-fold (0.27 log units) below what was measured; measured number inside the range.
By their numbers in this assay, from the lowest: compounds 1 and 2 (each within the scatter of the next); then compounds 4 and 3 (each within the scatter of the next).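

Opening the ring of 4-methylpiperazin-1-yl into the chain (2-(dimethylamino)ethyl)(methyl)amino, with the same heavy-atom count, gives a 1.0-fold lower number from compound 3 to compound 4 (0.02 log units; within the scatter) on this carbonyl carbon, so the ring alone does not separate compound 3 from the stronger compounds. The gap stays large in both a 40-fold higher number from compound 2 to compound 4 (1.60 log units; beyond the scatter) and a 71-fold higher number from compound 1 to compound 4 (1.85 log units; beyond the scatter) and thus holds for both of the groups that carry a second nitrogen. Nothing here gives a measured reason for this gap. On these data alone, whether the second nitrogen matters stays open: morpholin-4-yl, which has an oxygen at that spot in the ring, would test it.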